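From cyclohexyl to cyclobutyl on a carbonyl carbon

The source may hold more compounds than are shown below. What is called first, only, known or untested is meant among the compounds shown, and "the series" means these compounds.

Three amides sharing one core have been measured in a functional assay on SK-BR-3 cells (Homo sapiens) for antiproliferative activity (on this read-out higher numbers stand for weaker inhibition and lower numbers for stronger inhibition), and they fall into two groups. Compound 1 (`CO[C@@H]1[C@@H](O)[C@@H](O)[C@H](Oc2ccc3cc(NC(=O)C4CC4)c(=O)oc3c2C)OC1(C)C`), with cyclopropyl on the carbonyl carbon, gives 517000 nM and stands apart. Compound 2 (`CCCCCCC(=O)Nc1cc2ccc(O[C@@H]3OC(C)(C)[C@H](OC)[C@@H](O)[C@H]3O)c(C)c2oc1=O`), with hexyl there, gives 58300 nM and compound 3 (`CO[C@@H]1[C@@H](O)[C@@H](O)[C@H](Oc2ccc3cc(NC(=O)C4CCCCC4)c(=O)oc3c2C)OC1(C)C`), with cyclohexyl, gives 46800 nM and so shares the low end of the numbers with compound 2.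

The change to compound 4 (`CO[C@@H]1[C@@H](O)[C@@H](O)[C@H](Oc2ccc3cc(NC(=O)C4CCC4)c(=O)oc3c2C)OC1(C)C`), not yet measured, is cyclobutyl in place of cyclohexyl on a carbonyl carbon (in words, cyclobutyl in place of cyclohexyl on a carbonyl carbon). The most relevant evidence is the large step of an 11-fold lower number from compound 1 to compound 3 (1.04 log units; beyond the scatter) where cyclohexyl replaces cyclopropyl at the same place. The step of an 8.9-fold lower number from compound 1 to compound 2 (0.95 log units; beyond the scatter) is of similar size, while the step of a 1.2-fold lower number from compound 2 to compound 3 (0.10 log units; within the scatter) stays within the scatter. Cyclobutyl is a smaller ring than cyclohexyl and a larger one than cyclopropyl, so compound 4 is expected to fall somewhere inside the large gap between compound 3 and compound 1. Going by the values given here, the expected change is a 3.2-fold higher number from compound 3 to compound 4 (0.51 log units; beyond the scatter) towards a higher number, although no measured compound yet carries cyclobutyl. The estimate for compound 4 is 150000 nM with an expected range from 60000 nM to 400000 nM as the likely span of a measurement.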

Compound 4, half-maximal inhibitory concentration: 220000 nM
Beside the measured number, compound 4's estimate is 1.5-fold (0.17 log units) below it; measured number inside the range.
By their numbers in this assay, from the lowest: compounds 3 and 2 (each within the scatter of the next); then compound 4; then compound 1.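

In this assay the carbonyl position now holds a third ring size, and cyclobutyl joins neither earlier group: a 4.7-fold higher number from compound 3 to compound 4 (0.67 log units; beyond the scatter) separates it from the cyclohexyl amide, while a 2.4-fold lower number from compound 1 to compound 4 (0.37 log units; beyond the scatter) separates it from the cyclopropyl amide. Compounds 1, 4 and 3 therefore form a graded series in which the number falls at each step from cyclopropyl through cyclobutyl to cyclohexyl, with none of the three going against that order, and the open-chain hexyl amide also stands clear of the cyclobutyl amide, with a 3.8-fold higher number from compound 2 to compound 4 (0.58 log units; beyond the scatter). Nothing available accounts for this grading, so the series records an order and gives no reason for it.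

The compounds shown leave open whether cyclopentyl would continue the series smoothly or already reach the level of compounds 2 and 3. They also leave open whether cycloheptyl, phenyl or a chain longer than hexyl would take the number lower still, or whether the values stop falling beyond cyclohexyl.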